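Series notes: formyl added to compound 3

The source may hold more compounds than are shown below. What is called first, only, known or untested is meant among the compounds shown, and "the series" means these compounds.

Measured so far:
compound 1 `O=Cc1c(-c2ccccc2)sc2ccccc12` 37%
compound 2 `N#Cc1c(-c2ccc(Cl)cc2)sc2ccccc12` 18%
compound 3 `N#Cc1ccccc1-c1cc2ccccc2s1` 39%

In a functional assay on MCF7R cells (Homo sapiens) for cytotoxicity, tested at 10 uM (a higher number here means more inhibition at the concentration tested (going by the name of the read-out), a lower number less inhibition), compound 3 gives the highest of the three numbers; the gap to compound 1 lies within the usual scatter, so the two cannot be ordered, while the gap to compound 2 lies beyond it. Compound 4 `N#Cc1ccccc1-c1sc2ccccc2c1C=O` has not been measured. It differs from compound 3 in one place: formyl in place of hydrogen on an aromatic carbon. Within the data shown here, no step between measured compounds isolates this change. Compound 1 carries the same formyl group on its core and gives 37%, a number within the scatter of compound 3. The step of a number 1 percentage points lower from compound 3 to compound 4 (within the scatter) is therefore expected to be small, in no set direction, and not beyond the scatter. For compound 4 the expected value is 38%, within 24% to 52%.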

Compound 4, a percentage reported as inhibition, at one concentration (the size of the read-out at that concentration, not a potency): 33%
The estimate for compound 4 lay 5 percentage points above the measured number; measured number inside the range.
By their numbers in this assay, from the lowest: compound 2; then compounds 4, 1 and 3 (each within the scatter of the next).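

In this assay, formyl in place of hydrogen on an aromatic carbon of the five-membered ring reads as a number 6 percentage points lower from compound 3 to compound 4 (within the scatter), so this position carries the group without a step beyond the scatter. The step that adds cyano reads as a number 4 percentage points lower from compound 1 to compound 4 (within the scatter), so formyl and cyano together in one compound give no step beyond the scatter from either single-group compound. No measurement here offers an explanation for these numbers. On these data alone, whether an amine or a carboxylic acid at this position would give a step beyond the scatter stays open. Also open, as far as these compounds go, is how an amide in place of the nitrile would read.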